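This account rests on a few compounds, and the source may have more. Where it says the series, first, only, none or still open, it means among the compounds named here.

Of the compounds shown here, three built on the same core have been measured in a functional assay on YAC-1 cells (Mus musculus) for activation; on this read-out higher numbers stand for an effect only at larger amounts of compound and lower numbers for an effect already at smaller amounts. Compound 1 `Nc1nc(O)c2c(n1)n(C1OC(CO)[C@@H](O)[C@H]1O)c(=O)n2Cc1ccc(Cl)c(Cl)c1` gives 110 uM. Compound 2 `Nc1nc(O)c2c(n1)n(C1OC(CO)[C@@H](O)[C@H]1O)c(=O)n2Cc1ccc(Cl)cc1` gives 180 uM. Compound 3 `NC(=O)Cn1c(=O)n(C2OC(CO)[C@@H](O)[C@H]2O)c2nc(N)nc(O)c21` gives 90 uM, the lowest of the three numbers, although its gaps to compound 1 and compound 2 both fall within the scatter, so no ordering among them can be claimed.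

The next compound, compound 4 `Nc1nc(O)c2c(n1)n(C1OC(CO)[C@@H](O)[C@H]1O)c(=O)n2Cc1ccc([N+](=O)[O-])cc1`, is not yet measured. Its change from compound 3 is 4-nitrophenyl in place of carbamoyl on a saturated chain carbon bound to an aromatic nitrogen. Cut one bond further out, the same change reads carbamoylmethyl to 4-nitrobenzyl.

Among the measured compounds shown here, two measured steps bear on this, both in the opposite direction. Replacing an aryl group by carbamoyl gave a 1.2-fold lower number from compound 1 to compound 3 (0.09 log units; within the scatter) and a 2.0-fold lower number from compound 2 to compound 3 (0.30 log units; within the scatter). Neither moved the number beyond the scatter, so going back from carbamoyl to an aromatic ring in this assay is expected to do little, at most nudging the number upward.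

Compound 4 is therefore estimated to give 130 uM, with a range from 55 uM to 310 uM, meaning an expected step of a 1.4-fold higher number from compound 3 to compound 4 (0.16 log units; within the scatter), inside the usual scatter.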

Compound 4, concentration for half-maximal effect: 48 uM
Compound 4: middle estimate off by 2.7-fold (0.43 log units), on the high side, and the stated range ends above it.
By their numbers in this assay, from the lowest: compounds 4, 3, 1 and 2 (each within the scatter of the next, the first and the last beyond it).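

At the saturated chain carbon bound to an aromatic nitrogen, this assay now shows that an aromatic ring can stand in place of carbamoyl without any clear penalty: the change to 4-nitrophenyl gives a 1.9-fold lower number from compound 3 to compound 4 (0.27 log units; within the scatter) and so cannot be ranked on this read-out. The new information lies in what the ring carries, since two modest steps now clear the scatter, the first being a 3.8-fold lower number from compound 2 to compound 4 (0.57 log units; beyond the scatter) for nitro in place of chloro on an aromatic carbon, and the second 2.3-fold lower number from compound 1 to compound 4 (0.36 log units; beyond the scatter) for 4-nitrophenyl in place of 3,4-dichlorophenyl. No measurement on hand speaks to what lies behind these differences.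

On these data alone, the set holds only chloro, 3,4-dichloro and nitro variants of the benzyl group, so it remains open whether an amine or a carboxylic acid on the same ring would fall with nitro or with chloro. Also open, as far as these compounds go, is whether a longer chain between the ring and the aromatic nitrogen would keep the number of compound 4, or whether a plain phenyl ring would already do so.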